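Swapping a furan for a dimethoxyphenyl in rat paw edema

A few compounds are considered here, and "the series" means these few. Any claim that something is new, unique, unknown or untested is made for them only; others in the source may bear on it.

Of the compounds shown here, three have been tested in a functional assay on the whole organism (strain albino) for inhibition, with Rattus norvegicus as the target, read by paw edema, with stated times of 30 min and 3 h, at a dose of 100 mg/kg by the oral route; a lower number here means less inhibition, a higher number more inhibition at the dose given (going by the name of the read-out). Compound 1 `COc1ccc(C2=NN(C(=O)CO[N+](=O)[O-])C(c3ccco3)C2)cc1OC` gives 43%. Compound 2 `COc1ccc(C2CC(c3ccc(OC)c(OC)c3)=NN2C(=O)CO[N+](=O)[O-])c(OC)c1` gives 58%. Compound 3 `COc1ccc(C2=NN(C(=O)C(C)Br)C(c3ccco3)C2)cc1OC` gives 42%. A fourth, compound 4 `COc1ccc(C2CC(c3ccc(OC)c(OC)c3)=NN2C(=O)C(C)Br)c(OC)c1`, has not yet been measured in this assay.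

Compound 2 arises from compound 1 by one change, (2,4-dimethoxyphenyl in place of furan-2-yl on a saturated ring carbon), and this change brought a number 15 percentage points higher from compound 1 to compound 2 (beyond the scatter). Compound 3 arises from compound 1 by a different change, (1-bromoethyl in place of (nitrooxy)methyl on a carbonyl carbon), which gave a number 1 percentage points lower from compound 1 to compound 3 (within the scatter), so compound 1 and compound 3 cannot be told apart by this measurement, while compound 2 stands beyond the scatter from both.

Compound 4 arises from compound 3 by 2,4-dimethoxyphenyl in place of furan-2-yl on a saturated ring carbon. Among the measured compounds shown here, this is the same kind of change as the one from compound 1 to compound 2, but the surroundings are not identical: in compound 1 the ring atom next to the site bears a ((nitrooxy)methyl)carbonyl group (7 heavy atoms), whereas in compound 3 it bears a (1-bromoethyl)carbonyl group (5 heavy atoms). Since that difference between the two cores itself made only a number 1 percentage points lower from compound 1 to compound 3 (within the scatter), the step is expected to repeat at roughly its earlier size, a number 14 percentage points higher from compound 3 to compound 4 (beyond the scatter), in this assay. Compound 4 is therefore estimated at 56% in this assay, with a plausible range from 44% to 68%.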

Compound 4, a percentage reported as inhibition, in the whole organism at one dose (the size of the read-out at that dose, not a potency): 69%
Beside the measured number, compound 4's estimate is 13 percentage points below it, outside the stated range (above it).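

In this assay, putting 2,4-dimethoxyphenyl in place of furan-2-yl on the core bearing the (1-bromoethyl)carbonyl group gave a number 27 percentage points higher from compound 3 to compound 4 (beyond the scatter), so the change pushed the number in the same direction on both cores, and the two steps cannot be told apart in size: the same change on two cores in this assay, a number 15 percentage points higher (beyond the scatter) from compound 1 to compound 2 and a number 27 percentage points higher (beyond the scatter) from compound 3 to compound 4, 12 percentage points apart, within the scatter of two such steps. The other change, 1-bromoethyl in place of (nitrooxy)methyl, gave a number 11 percentage points higher from compound 2 to compound 4 (beyond the scatter), and although this step lies beyond the scatter while its earlier counterpart lies within it, the gap between the two is still within the scatter of two such steps: the same change on two cores in this assay, a number 1 percentage points lower (within the scatter) from compound 1 to compound 3 and a number 11 percentage points higher (beyond the scatter) from compound 2 to compound 4, 12 percentage points apart, within the scatter of two such steps. This supports carrying the aryl change between these two cores, but two cores are a small sample, so it does not show that the change would work on other cores, and it cannot settle whether the step is truly larger on one core than on the other.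

The compounds shown leave open whether the rise needs both methoxy groups, or whether a plain phenyl or a 4-methoxyphenyl on that ring carbon would do the same. They also leave open how a different group on the carbonyl carbon, such as an aminomethyl group or a longer chain, would behave.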